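The source may report more compounds than this note shows. Statements on the series, on what has been measured and on what is new or still open speak of the compounds shown alone.

Measured compounds in a functional assay on BJAB cells (Homo sapiens) for antiproliferative activity, with a stated time of 4 days; on this read-out higher numbers stand for an effect only at larger amounts of compound and lower numbers for an effect already at smaller amounts:

- compound 1, `Cc1ccc(-c2c(C)nn(-c3nc(-c4ccc(Cl)c(Cl)c4)c(SC(C)C)s3)c2C(=O)O)cc1`: 3800 nM
- compound 2, `COc1cc(-c2c(C)nn(-c3nc(-c4ccc(Cl)c(Cl)c4)c(SC(C)C)s3)c2C(=O)O)cc(C(F)(F)F)c1`: 1380 nM
- compound 3, `COc1ccccc1-c1c(C)nn(-c2nc(-c3ccc(Cl)c(Cl)c3)c(SC(C)C)s2)c1C(=O)O`: 14700 nM

Compound 3 gives the highest number of the three in this assay: the step of a 3.9-fold higher number from compound 1 to compound 3 (0.59 log units; beyond the scatter) and the step of an 11-fold higher number from compound 2 to compound 3 (1.03 log units; beyond the scatter) both show it needing more compound than its two neighbours. Compound 4, `CNc1cc(-c2c(C)nn(-c3nc(-c4ccc(Cl)c(Cl)c4)c(SC(C)C)s3)c2C(=O)O)ccn1`, has not been measured; it differs from compound 3 by 2-(methylamino)pyridin-4-yl in place of 2-methoxyphenyl on an aromatic carbon.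

The two measured steps that bear on this change both replace one aromatic group on the same carbon of the shared core. The step of a 3.9-fold higher number from compound 1 to compound 3 (0.59 log units; beyond the scatter) and the step of an 11-fold higher number from compound 2 to compound 3 (1.03 log units; beyond the scatter) both went to higher numbers when 2-methoxyphenyl entered. Compound 4 removes that 2-methoxyphenyl again and brings in a 2-(methylamino)pyridin-4-yl group, which is closer in substitution pattern to the 4-methylphenyl of compound 1 than to the 2-methoxyphenyl of compound 3. Within the data shown here, a step back to lower numbers is therefore expected, of a size comparable to the step of a 3.9-fold higher number from compound 1 to compound 3 (0.59 log units; beyond the scatter), though no measured compound carries a nitrogen-containing ring here, so the range is kept wide.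

The expected step from compound 3 to compound 4 is a 4.9-fold lower number from compound 3 to compound 4 (0.69 log units; beyond the scatter). Compound 4 is estimated at 3000 nM, with a range from 900 nM to 10000 nM.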

Compound 4, half-maximal effective concentration: 18000 nM
The estimate for compound 4 lay 6.0-fold (0.78 log units) below the measured number, outside the stated range (above it).
By their numbers in this assay, from the lowest: compound 2; then compound 1; then compounds 3 and 4 (each within the scatter of the next).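

In this assay, replacing 2-methoxyphenyl with 2-(methylamino)pyridin-4-yl gives a 1.2-fold higher number from compound 3 to compound 4 (0.09 log units; within the scatter), so two groups that differ in ring atoms and in their substituent cannot be told apart at this position. The same replacement of the other two aromatic groups gives a 4.7-fold higher number from compound 1 to compound 4 (0.68 log units; beyond the scatter) and a 13-fold higher number from compound 2 to compound 4 (1.12 log units; beyond the scatter), which places compound 4 with compound 3 and shows that a ring containing nitrogen does not bring the number back towards those of compound 1 or compound 2. Nothing available explains why these two different groups read alike.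

The compounds shown cannot separate the contribution of the ring nitrogen from that of the methylamino group. A plain pyridin-4-yl group and a 2-aminopyridin-4-yl group on this carbon would begin to pull those two apart.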